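Fluoro to Trifluoromethyl: Expecting the Value of Compound 4

The source may hold more compounds than are shown below. What is called first, only, known or untested is meant among the compounds shown, and "the series" means these compounds.

Of the compounds shown here, three have been measured in a functional assay on BGC-823 cells (Homo sapiens) for antiproliferative activity, read by MTT assay, tested at 1 uM; on this read-out lower numbers stand for a weaker effect and higher numbers for a stronger effect at the one concentration tested. Compound 1, with the structure `COc1cc(C2=NN(C(C)=O)C(c3cccc(F)c3)O2)cc(OC)c1OC`, gives 14.7%, the second highest of the three numbers. Its nearest neighbour is compound 3, `COc1cc(C(=O)N/N=C/c2cccc(F)c2)cc(OC)c1OC`, which gives 13.6%, a value within the usual scatter of that of compound 1, so the two cannot be told apart. The furthest is compound 2, `COc1cc(C(=O)N/N=C/c2ccc(C(F)(F)F)cc2)cc(OC)c1OC`, which gives 47.4%, clearly beyond the scatter and well above compound 1. Among the measured compounds shown here, compound 2 carries a trifluoromethyl group where compound 3 carries a fluoro, and the two values show the higher number on the trifluoromethyl side; no single step between them is recorded, so this is only what the two numbers show.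

Compound 4, `COc1cc(C2=NN(C(C)=O)C(c3cccc(C(F)(F)F)c3)O2)cc(OC)c1OC`, has not yet been measured. It differs from compound 1 by trifluoromethyl in place of fluoro on an aromatic carbon. For the measured compounds named here, no measured pair of compounds shows this exact change on the shared core of compound 1, so the size of the step is uncertain. A modest rise is expected, with the step of a number 11.3 percentage points higher from compound 1 to compound 4 (beyond the scatter), because compound 2 gives 47.4% while compound 3 gives 13.6%. For compound 4 the expected value is 26%, with a range from 10% to 45%.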

Compound 4, a percentage reported as inhibition, at one concentration (the size of the read-out at that concentration, not a potency): 27.9%
Compound 4: the middle estimate sits 1.9 percentage points below what was measured, within the range that was stated.
By their numbers in this assay, from the lowest: compounds 3 and 1 (each within the scatter of the next); then compound 4; then compound 2.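

Among the compounds shown here, this is the first direct reading of the change from 3-fluorophenyl to 3-(trifluoromethyl)phenyl with the rest of the molecule held fixed. In this assay, trifluoromethyl in place of fluoro on this aromatic carbon gives a number 13.2 percentage points higher from compound 1 to compound 4 (beyond the scatter), so the read-out on this core does respond to what sits at this position, and the larger group does not cost activity here. This rests on a single pair of compounds at one concentration, so it describes the size of the effect at that concentration and not a potency. No measurement shown here explains why the number moves with this change.

The compounds shown leave open how a chlorine atom, an amine or a carboxylic acid on the same aromatic carbon would read, and so whether the rise follows the size of the group or something else about trifluoromethyl. They also leave open whether the same exchange would give a step of similar size on a different core, such as that of compound 3.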